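Phenyl to Fluorinated Dimethylphenyl: Expected Effect on Solubility

This account rests on a few compounds, and the source may have more. Where it says the series, first, only, none or still open, it means among the compounds named here.

Measured compounds:
compound 1, `Cc1cc(C)cc(NC(=O)COc2cc(C)nc3ccccc23)c1`: 55000 nM
compound 2, `COc1ccc2nc(C)cc(OCC(=O)Nc3ccccc3)c2c1`: 63000 nM

Of the compounds shown here, two have so far been tested in a physicochemical assay for solubility, in phosphate buffer, measured as kinetic solubility, with a stated time of 1 h, at pH 7.4; a higher number here means a more soluble compound, a lower number a less soluble compound. Compound 1 `Cc1cc(C)cc(NC(=O)COc2cc(C)nc3ccccc23)c1` gives 55000 nM in this assay. Compound 2 `COc1ccc2nc(C)cc(OCC(=O)Nc3ccccc3)c2c1` gives 63000 nM in this assay, and the two values lie within the usual scatter of each other, so neither compound can be called more or less soluble than the other.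

Compound 3 `COc1ccc2nc(C)cc(OCC(=O)Nc3cc(C)c(F)c(C)c3)c2c1` has not yet been measured. Compared with compound 2, the change is 4-fluoro-3,5-dimethylphenyl in place of phenyl on an amide-type nitrogen. Among the measured compounds shown here, no pair of measured compounds differs by exactly this kind of change, so the size of the step cannot be read from the data, only expected. A moderate downward step beyond the scatter is expected, as the change adds atoms to the aromatic ring on the amide nitrogen without adding any hydrogen-bond donor or acceptor. For compound 3 the expected value in this assay is 25000 nM, with a range from 8000 nM to 70000 nM. This estimate corresponds to an expected step of a 2.5-fold lower number from compound 2 to compound 3 (0.40 log units; beyond the scatter).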

Compound 3, solubility: 31500 nM
For compound 3 the middle estimate is 1.3-fold (0.10 log units) below the measured one; measured number inside the range.
By their numbers in this assay, from the lowest: compounds 3, 1 and 2 (each within the scatter of the next).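

In this assay, among the compounds shown here, placing 4-fluoro-3,5-dimethylphenyl instead of phenyl on the amide-type nitrogen gives a 2.0-fold lower number from compound 2 to compound 3 (0.30 log units; within the scatter), the first direct comparison at this position. The group that enters has 9 heavy atoms against 6 for phenyl, and neither group has a hydrogen-bond donor or acceptor, yet these two compounds cannot be told apart in this measurement. No other measurement shown explains this result.

As far as these compounds go, the fluorine and the two methyl groups enter together, so the contribution of each one alone remains open. Also open, from the compounds shown here alone, is how this comparison would look with a group of a different kind on the amide-type nitrogen, such as a phenyl carrying an amine or a carboxylic acid.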